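A methyl added on the hydroxy chain of compound 1

A few compounds are considered here, and "the series" means these few. Any claim that something is new, unique, unknown or untested is made for them only; others in the source may bear on it.

Measured compounds:
compound 1, `CCOC(=O)c1cnn(CC(C)O)c1NC(=O)NCc1ccccc1`, gives 15 nM in a functional assay on cells (Neutrophil, Homo sapiens) for inhibition, with a stated time of 10 min; a higher number here means a weaker inhibitor, a lower number a stronger inhibitor
compound 2, `CCOC(=O)c1cnn(CC(C)O)c1NC(=O)Nc1cccc(F)c1`, gives only a limit, > 10 nM, in this assay
compound 3, `CCOC(=O)c1cnn(CC(C)O)c1NC(=O)NC(C)C`, gives 90 nM in this assay

Compound 1 holds the lowest of the two numbers given. Its nearest neighbour is compound 3, reached by a 6.0-fold higher number from compound 1 to compound 3 (0.78 log units; beyond the scatter), a swap of isopropyl for benzyl on an amide-type nitrogen. The steps a step that the limit leaves unreadable from compound 1 to compound 2 and a step that the limit leaves unreadable from compound 2 to compound 3 cannot be read because the value of compound 2 is a limit (the limit of > 10 nM in this assay, at which 1 of the 3 values shown sits).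

Compound 4, `CCOC(=O)c1cnn(CC(O)CC)c1NC(=O)NCc1ccccc1`, differs from compound 1 by methyl in place of hydrogen on a saturated chain carbon, two bonds along the chain from an oxygen on a saturated carbon; read one bond further out, methyl becomes ethyl and 2-hydroxypropyl becomes 2-hydroxybutyl. For the measured compounds named here, none of the measured steps touches this place: all three change the group on the amide-type nitrogen, and the hydroxy chain is the same in compounds 1, 2 and 3. Going by the values given here, there is thus no measured step that speaks for a shift in either direction, and the expectation is a step within the scatter. Compound 4 is expected to give about 15 nM, with a range from 5 nM to 45 nM. The expected step is no change at the digits printed from compound 1 to compound 4 (within the scatter).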

Compound 4, half-maximal inhibitory concentration: > 10 nM
Compound 4 gave a limit, no number; the forecaster's own chance of this, stated with the estimate: 10%; the middle value does not contradict the limit.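

Compound 4 gives only a limit of > 10 nM in this assay, so the step that joins it to compound 1 cannot be read: the limit of > 10 nM in this assay, at which 2 of the 4 values shown sit. The compounds shown leave open how the 2-hydroxybutyl chain of compound 4 compares with the 2-hydroxypropyl chain of compound 1 in this assay.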